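Sulfamoylphenyl for difluorophenyl on a thiazole acetic acid

This account rests on a few compounds, and the source may have more. Where it says the series, first, only, none or still open, it means among the compounds named here.

The study compares two measured antagonists and one still awaiting its number. Compound 1, `O=C(O)Cc1sc(COc2ccc(Cl)cc2)nc1-c1ccc(Cl)cc1`, was tested in an in vitro functional assay on HEK285-7 cells for antagonist activity at prostaglandin D2 receptor 2 (Homo sapiens), read by BRET and beta-arrestin recruitment (on this read-out lower numbers stand for smaller maximal responses and higher numbers for larger maximal responses), and compound 1 gives 50%. Among the compounds with values here, compound 2, `O=C(O)Cc1sc(C(c2ccc(F)cc2)c2ccc(F)cc2)nc1-c1cc(F)cc(F)c1`, is the higher of the two on this read-out, and in this assay compound 2 gives 80%, a value higher than that of compound 1 by a margin beyond the usual scatter; no single-point step links these two, so only their two values can be set side by side.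

Compound 3, `NS(=O)(=O)c1cccc(-c2nc(C(c3ccc(F)cc3)c3ccc(F)cc3)sc2CC(=O)O)c1`, differs from compound 2 in one place: 3-sulfamoylphenyl in place of 3,5-difluorophenyl on an aromatic carbon. Within the data shown here, the group that enters carries one hydrogen-bond donor and two acceptors where the group that leaves had none, but with only two measured compounds no pattern connects this kind of exchange to the maximal response. The expected step of a number 5 percentage points lower from compound 2 to compound 3 (within the scatter) is therefore small, and compound 3 is expected to fall near compound 2, with the usual scatter allowed. The estimate for compound 3 in this assay is 75%, within a range from 50% to 95%.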

Compound 3, largest response reached (reported as efficacy), in percent of the reference or control that the assay uses: 55%
The estimate for compound 3 lay 20 percentage points above the measured number, and the stated range covers the measured number.
By their numbers in this assay, from the lowest: compounds 1 and 3 (each within the scatter of the next); then compound 2.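

In this assay, replacing 3,5-difluorophenyl with 3-sulfamoylphenyl on the aromatic carbon next to the ring nitrogen gives a number 25 percentage points lower from compound 2 to compound 3 (beyond the scatter). This is the only single-place step among the compounds shown, and it establishes that the maximal response at this position depends on the group it carries, even with the rest of the molecule held constant. Both groups contain one six-membered aromatic ring of carbon only, so the exchange lies in what that ring carries: 2 fluorine atoms leave, while a sulfamoyl group with 1 hydrogen-bond donor and 2 hydrogen-bond acceptors enters, and no measurement shown here accounts for the size of the step.

This single step cannot separate the loss of the fluorine atoms from the gain of the sulfamoyl group, so an unsubstituted phenyl at this position would be the natural point of comparison. As far as these compounds go, it also remains open whether a methanesulfonyl group or a carboxylic acid in place of the sulfamoyl group would give a maximal response nearer that of compound 3 or that of compound 2.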